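A few compounds are considered here, and "the series" means these few. Any claim that something is new, unique, unknown or untested is made for them only; others in the source may bear on it.

Compound 3 `CC(C)c1n[nH]c2c(NCc3ccc(-c4ccccn4)cc3)nc(SCC(C)(C)O)nc12` is the starting point. In a functional assay on HT cells (Homo sapiens) for antiproliferative activity, read by fluorescence, with a stated time of 72 h (on this read-out higher numbers stand for weaker inhibition of growth and lower numbers for stronger inhibition of growth), compound 3 gives 507 nM, the second highest of the three numbers measured. Its nearest neighbour is compound 2 `C=CCSc1nc(NCc2ccc(-c3ccccn3)cc2)c2[nH]nc(C(C)C)c2n1`, which gives 1010 nM; the step of a 2.0-fold lower number from compound 2 to compound 3 (0.30 log units; within the scatter) is within the scatter. Furthest away is compound 1 `CC(C)c1n[nH]c2c(NCc3ccc(-c4ccccn4)cc3)nc(SCC(N)=O)nc12`, which gives 192 nM, and the step of a 2.6-fold higher number from compound 1 to compound 3 (0.42 log units; beyond the scatter) lies beyond the scatter. Compound 4 `COCSc1nc(NCc2ccc(-c3ccccn3)cc2)c2[nH]nc(C(C)C)c2n1` differs from compound 3 in one place: methoxy in place of 1-hydroxy-1-methylethyl on a saturated chain carbon bound to a sulfur. All three measured steps alter this same chain carbon bound to a sulfur; the steps of a 5.3-fold higher number from compound 1 to compound 2 (0.72 log units; beyond the scatter) and a 2.6-fold higher number from compound 1 to compound 3 (0.42 log units; beyond the scatter) were modest, while the step of a 2.0-fold lower number from compound 2 to compound 3 (0.30 log units; within the scatter) stayed within the scatter. For compound 4 the step of a 1.3-fold higher number from compound 3 to compound 4 (0.11 log units; within the scatter) is expected to stay within the scatter as well. Compound 4 is estimated at 650 nM, with a range from 250 nM to 1700 nM.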

Compound 4, concentration for 50% growth inhibition: 340 nM
For compound 4 the middle estimate is 1.9-fold (0.28 log units) above the measured one, and the stated range covers the measured number.
By their numbers in this assay, from the lowest: compounds 1, 4, 3 and 2 (each within the scatter of the next, the first and the last beyond it).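

In this assay, methoxy, which has no hydrogen-bond donor, stays within the scatter of the donor-bearing 1-hydroxy-1-methylethyl (a 1.5-fold lower number from compound 3 to compound 4 (0.17 log units; within the scatter)), so a donor in that group is not required at this position. Methoxy also stays within the scatter of carbamoyl (a 1.8-fold higher number from compound 1 to compound 4 (0.25 log units; within the scatter)), yet replacing vinyl with it gives a modest step beyond the scatter (a 3.0-fold lower number from compound 2 to compound 4 (0.47 log units; beyond the scatter)). No measurement here explains these steps. From the compounds shown here alone, what remains open is how an amine, a carboxylic acid or a longer chain would behave on this saturated chain carbon bound to a sulfur.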